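Pyrrolidin-1-yl in place of piperidin-1-yl on a thiocarbonyl carbon

This account rests on a few compounds, and the source may have more. Where it says the series, first, only, none or still open, it means among the compounds named here.

Of the compounds shown here, three have so far been measured in a functional assay on LM7 cells (Homo sapiens) for antiproliferative activity, read by MTT assay, with a stated time of 72 h; on this read-out higher numbers stand for weaker inhibition and lower numbers for stronger inhibition. Compound 1 (`COc1ccc2occ(CSC(=S)N3CCCCC3)c(=O)c2c1`) gives 4700 nM in this assay. Compound 2 (`O=c1cc(CSC(=S)N2CCCCC2)oc2cc(Cl)ccc12`) gives 13800 nM in this assay, the higher of the two numbers shown; its nearest neighbour is compound 1, whose number is lower by a gap beyond the scatter of repeated measurements. For compound 3 (`CCOC(=O)c1cc(=O)c2cc(CSC(=S)N(C(C)C)C(C)C)ccc2o1`) this assay reports only a limit, > 25000 nM, and not a number. That limit is the one described as the limit of > 25000 nM in this assay, at which 1 of the 3 values shown sits.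

Compound 4 (`O=c1cc(CSC(=S)N2CCCC2)oc2cc(Cl)ccc12`) remains to be measured in this assay. It differs from compound 2 in one place: pyrrolidin-1-yl in place of piperidin-1-yl on a thiocarbonyl carbon. For the measured compounds named here, no measured pair in this set shows what such a swap does, so no step size is known for it. The writer expects the number for compound 4 to stay close to that of compound 2. The step of a 1.2-fold lower number from compound 2 to compound 4 (0.06 log units; within the scatter) implied by this estimate is expected to fall within the scatter. The estimate for compound 4 in this assay is 12000 nM, with a range from 5000 nM to 28000 nM.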

Compound 4, half-maximal inhibitory concentration: > 25000 nM
Compound 4 was reported as a limit (the forecaster's own chance of this, stated with the estimate: 20%); at least 2.0-fold (0.31 log units) between middle value and limit.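

In this assay, for the compounds shown here, pyrrolidin-1-yl in place of piperidin-1-yl on a thiocarbonyl carbon gives an at least 1.8-fold higher number from compound 2 to compound 4 (0.25 log units; that floor lies within the scatter), and this is the only measured pair that changes this position. On these data alone, the swap therefore gives no sign of a gain at this position, but the printed floor alone does not establish a loss beyond the scatter, and the true size of the step remains unknown. Compound 4 is reported only as a limit, so the result fixes no number for it: the limit of > 25000 nM in this assay, at which 2 of the 4 values shown sit.

The compounds shown leave open whether the ring on this thiocarbonyl carbon can be changed more widely, for instance to azepan-1-yl or morpholin-4-yl, while keeping the activity of compound 2. They also leave open whether the same swap would have a comparable effect on the core of compound 1.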